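Sulfonyl in place of carbonyl on the ring nitrogen

The compounds below may be only part of what the source reports. "The series", "measured", "known", "first", "only" and "open" are said of these compounds alone.

Measured so far:
compound 1, `O=C(CCCc1cn(S(=O)(=O)c2cccs2)c2ccccc12)NCCCn1ccnc1`: 5500 nM; 5010 nM (2 entries)
compound 2, `O=C(CCCc1cn(C(=O)c2cccs2)c2ccccc12)NCCCn1ccnc1`: 21400 nM

In an assay on isolated protein for activation of Insulin-degrading enzyme (Homo sapiens), read by fluorescence, with stated times of 10 min and 20 min (on this read-out lower numbers stand for an effect already at smaller amounts and higher numbers for an effect only at larger amounts of compound), compound 1 gives 5500 nM; 5010 nM (2 entries) across its repeated entries, while compound 2 gives 21400 nM. Compound 2 stands at the higher of the two numbers shown, and a further record of compound 2 in this assay carries no single number. The repeats of compound 1 are summarised in the several entries of compound 1 in this assay, 5500 nM; 5010 nM (2 entries) and sit close to one another.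

Compound 3, `O=C(CCCc1cn(S(=O)(=O)c2cccc(F)c2)c2ccccc12)NCCCn1ccnc1`, has not been measured in this assay. It differs from compound 2 by (3-fluorophenyl)sulfonyl in place of (thiophen-2-yl)carbonyl on an aromatic nitrogen. Within the data shown here, no measured pair of compounds traces this exact step, so its size can only be expected from the numbers above: the sulfonyl-bearing compound 1 gives the lower number and the carbonyl-bearing compound 2 the higher, and compound 3 carries a sulfonyl group. Compound 3 is therefore expected to come in at a lower number than compound 2, an expected step of a 3.6-fold lower number from compound 2 to compound 3 (0.55 log units; beyond the scatter). For compound 3 the estimate is 6000 nM, with a range from 2500 nM to 15000 nM.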

Compound 3, half-maximal effective concentration: 10200 nM
Compound 3: middle estimate off by 1.7-fold (0.23 log units), on the low side; the range from low to high includes it.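

In this assay, the aromatic nitrogen accepts a change of both the linking group and the ring, with a 2.1-fold lower number from compound 2 to compound 3 (0.32 log units; beyond the scatter). The entering (3-fluorophenyl)sulfonyl group is the larger of the two by heavy-atom count and brings a six-membered aromatic ring of carbon only, so this position is not limited to the five-membered aromatic ring of the (thiophen-2-yl)carbonyl group. Set against compound 3 at 10200 nM, the sulfonyl compound bearing the thiophen-2-yl ring shows no wide gap, and its repeats agree closely: the several entries of compound 1 in this assay, 5500 nM; 5010 nM (2 entries)

The step from compound 2 changes the linking group and the ring together, so the compounds shown leave open how much of it belongs to each, a split that a (3-fluorophenyl)carbonyl group on the same nitrogen would address. They also leave open what the fluorine contributes, which could be read against an unsubstituted phenylsulfonyl group, and whether a small methylsulfonyl group with no ring would hold the same level in this assay.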